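Deacetylating the ring amide of a coumarin-furoxan hybrid

The source may report more compounds than this note shows. Statements on the series, on what has been measured and on what is new or still open speak of the compounds shown alone.

In a functional assay on HepG2 cells (Homo sapiens) for inhibition, read by MTT assay, with a stated time of 48 h (on this read-out higher numbers stand for weaker inhibition and lower numbers for stronger inhibition), compound 2 `COc1cc2cc(NC(C)=O)c(=O)oc2cc1OCCCCOc1no[n+]([O-])c1S(=O)(=O)c1ccccc1` gives 3290 nM, which is the higher of the two numbers recorded so far. Its neighbour compound 1 `COc1cc2ccc(=O)oc2cc1OCCCCOc1no[n+]([O-])c1S(=O)(=O)c1ccccc1` gives 3250 nM in this assay, and the step of a 1.0-fold higher number from compound 1 to compound 2 (0.01 log units; within the scatter) corresponds to acetamido in place of hydrogen on an aromatic carbon. Compound 3 `COc1cc2cc(N)c(=O)oc2cc1OCCCCOc1no[n+]([O-])c1S(=O)(=O)c1ccccc1` has not yet been measured in this assay. It differs from compound 2 by hydrogen in place of acetyl on a nitrogen on an aromatic ring, so that the acetamido group of compound 2 becomes an amino group. Among the measured compounds shown here, the one measured step that bears on this site, the step of a 1.0-fold higher number from compound 1 to compound 2 (0.01 log units; within the scatter), shows that adding the whole acetamido group to compound 1 left the number where it was. Removing only the acetyl part of it is therefore expected to produce no step beyond the scatter in this assay, and the expected step of a 1.0-fold higher number from compound 2 to compound 3 (0.00 log units; within the scatter) is set close to zero. Compound 3 is accordingly estimated at 3300 nM in this assay, with a range from 1600 nM to 6800 nM.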

Compound 3, half-maximal inhibitory concentration: 2640 nM
Beside the measured number, compound 3's estimate is 1.3-fold (0.10 log units) above it; low and high end bracket the measured number.
By their numbers in this assay, from the lowest: compounds 3, 1 and 2 (each within the scatter of the next).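

In this assay, the data give a 1.2-fold lower number from compound 2 to compound 3 (0.10 log units; within the scatter), so cutting the acetamido group back to an amino group gives no step beyond the scatter. They also give a 1.2-fold lower number from compound 1 to compound 3 (0.09 log units; within the scatter), which places the amino group, like the acetamido group before it, within the scatter of the compound with hydrogen on this aromatic carbon; across hydrogen, amino and acetamido, this position therefore shows no difference that can be read in this assay. No accompanying measurement offers any explanation for how closely these three numbers lie together.

The compounds shown span only these three substituents, so it remains open whether a carboxylic acid, a nitrile, a dimethylamino group or an amide with a longer chain on this carbon would also stay within the scatter. All three compounds are also identical everywhere else and are compared in this one cell assay, so the data cannot say whether the same flat reading would hold with a change elsewhere in the molecule or on other cells.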